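The source may report more compounds than this note shows. Statements on the series, on what has been measured and on what is new or still open speak of the compounds shown alone.

Among the measured compounds shown here, compound 2, `COc1ccc(F)c(-c2ccc(Cc3ccc(N4C[C@@H](C(F)(F)F)C[C@H]4CC(=O)O)cc3)c(C)c2)c1`, is the only compound here with a numerical result: in a functional assay on HEK293 cells for agonist activity at Free fatty acid receptor 1 (Homo sapiens), read by HTRF and cAMP accumulation, with a stated time of 45 min (a higher number here means that more compound is needed for the effect, a lower number that less compound is needed), compound 2 gives 2400 nM. Compound 1, `Cc1ccccc1Oc1ccc(N2C[C@@H](C(F)(F)F)C[C@H]2CC(=O)O)cc1`, reaches only a limit of the assay: in this assay compound 1 gives > 20000 nM. Compound 3, `COc1ccc(F)c(-c2ccc(Cc3ccc(N4C[C@H](C(F)(F)F)C[C@@H]4CC(=O)O)cc3)c(C)c2)c1`, differs from compound 2 in the two compounds have the same atoms and bonds and differ only in configuration as drawn: 2 of 2 stereo elements differ (all stereocentres are inverted: mirror images); a stereocentre at a saturated ring carbon is drawn S in compound 2 and R in compound 3; a stereocentre at a saturated ring carbon is drawn S in compound 2 and R in compound 3. No measured step between two compounds is available, so the size of this change cannot be read from the data shown. Compound 3 is nevertheless expected to need more compound than compound 2, with a 6.3-fold higher number from compound 2 to compound 3 (0.80 log units; beyond the scatter) as the estimated step. Compound 3 is estimated at 15000 nM, expected to lie between 4000 nM and 40000 nM.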

Compound 3, half-maximal effective concentration: 210 nM
Estimate against measurement, compound 3: 71-fold (1.85 log units) above; the measured number lies below the stated range.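

In this assay, inverting both stereocentres at the saturated ring carbons gives an 11-fold lower number from compound 2 to compound 3 (1.06 log units; beyond the scatter). This is the first measured step among these compounds, and it shows that configuration at these two centres can by itself produce a large change in the number, beyond the scatter. The step can be assigned to configuration alone because no atom or bond changes: the fact that compounds 2 and 3 differ only in the configuration as drawn

Both centres change together here, and which of them accounts for the step remains open. As far as these compounds go, how the configuration of compound 3 would fare with a nitrile in place of the trifluoromethyl group also remains unknown.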